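From Isopropyl to Propyl on a Sulfur

The source may hold more compounds than are shown below. What is called first, only, known or untested is meant among the compounds shown, and "the series" means these compounds.

In an ADME assay on MT4 cells (Homo sapiens) for activation, read by MTT assay (on this read-out lower numbers stand for higher toxicity in this test and higher numbers for lower toxicity in this test), compound 3 `CCC(c1nc(SC(C)C)[nH]c(=O)c1C)c1c(F)cccc1F` gives > 30000 nM as a limit of the assay and not as a number. Compound 1 `CCCSc1nc(C(CC)c2c(F)cccc2Cl)c(C)c(=O)[nH]1` gives > 3000 nM in the same test, and this too is a limit. Compound 2 `CCCSc1nc(C(C)c2c(F)cccc2F)c(C)c(=O)[nH]1` gives > 3000 nM as a limit as well. Compound 3 therefore stands without a measured cytotoxic concentration, and the two other results shown are also limits, so the three cannot be placed in order.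

Compound 4 `CCCSc1nc(C(CC)c2c(F)cccc2F)c(C)c(=O)[nH]1` has not yet been measured. For the measured compounds named here, it has the same atoms as compound 3, joined differently, with propyl in place of isopropyl on a sulfur as the only change. Going by the values given here, no two measured compounds differ in just one place, so no measured step speaks directly to this change. Compound 1 carries propyl on a sulfur and gives > 3000 nM as a limit, so this group has not yet brought a numerical reading in the test. In this assay the estimated step of a number no higher from compound 3 to compound 4 (the limit leaves the size open) is expected to stay within the usual scatter, in neither direction. The expected value for compound 4 is 30000 nM with an estimated range from 6000 nM to 100000 nM and a good chance of only a limit once more.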

Compound 4, half-maximal cytotoxic concentration: > 3000 nM
Compound 4: only a limit was reported; the forecaster's own chance of this, stated with the estimate: 80%; the middle value does not contradict the limit.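

In this assay compound 4 also returns only a limit of the assay, as do compound 1, compound 2 and compound 3, so none of its steps from these three can be read. The compounds shown leave open whether propyl in place of isopropyl on a sulfur, or either other single change, shifts the cytotoxic concentration at all.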